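Compound 3: chloro in place of fluoro

This account rests on a few compounds, and the source may have more. Where it says the series, first, only, none or still open, it means among the compounds named here.

- compound 1 `C#Cc1cccc(NC(=O)CCc2cccc3c2B(O)OC3)c1` gives 1600 nM
- compound 2 `O=C(CCc1cccc2c1B(O)OC2)Nc1cccc(-c2ccc(F)cc2)c1` gives 250 nM

In a functional assay on MDA-MB-231 cells (Homo sapiens) for antiproliferative activity, read by MTT assay, with a stated time of 72 h (on this read-out lower numbers stand for stronger inhibition and higher numbers for weaker inhibition), compound 2 holds the lower of the two numbers, at 250 nM. Compound 3 `O=C(CCc1cccc2c1B(O)OC2)Nc1cccc(-c2ccc(Cl)cc2)c1` has not been measured. Relative to compound 2, it carries chloro in place of fluoro on an aromatic carbon, para to a large group: chloro in place of fluoro on an aromatic carbon.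

Within the data shown here, only one measured step is available: a 6.4-fold lower number from compound 1 to compound 2 (0.81 log units; beyond the scatter). It exchanged ethynyl for 4-fluorophenyl, a far larger change than this one, and it says nothing directly about exchanging one halogen for another. Among the measured compounds shown here, with no measured step of that kind, no shift beyond the scatter is expected in this assay, and no direction is favoured with confidence.

The expected outcome is a 1.1-fold lower number from compound 2 to compound 3 (0.04 log units; within the scatter). Compound 3 is estimated at 230 nM, with an expected range of 100 nM to 530 nM.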

Compound 3, half-maximal inhibitory concentration: 260 nM
The estimate for compound 3 lay 1.1-fold (0.05 log units) below the measured number; the range from low to high includes it.
By their numbers in this assay, from the lowest: compounds 2 and 3 (each within the scatter of the next); then compound 1.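

In this assay, chloro in place of fluoro on an aromatic carbon, para to a large group, gives a 1.0-fold higher number from compound 2 to compound 3 (0.02 log units; within the scatter), so this position accepts either halogen with no change that can be read. The gain over ethynyl is therefore not tied to fluoro: 4-chlorophenyl gives a 6.2-fold lower number from compound 1 to compound 3 (0.79 log units; beyond the scatter), and 4-fluorophenyl gave a 6.4-fold lower number from compound 1 to compound 2 (0.81 log units; beyond the scatter). No measurement at hand bears on why the two halogens read alike.

Open, on these data alone, is whether this position tolerates groups other than halogens, such as an amine, a carboxylic acid or a methoxy group, at the level of the halogen compounds. Also open, as far as these compounds go, is how an unsubstituted phenyl would read against 4-fluorophenyl and 4-chlorophenyl, which would show whether a halogen is needed here at all.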